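Ortho-substituent swap on the benzyl ether: methyl to cyano

The compounds below may be only part of what the source reports. "The series", "measured", "known", "first", "only" and "open" are said of these compounds alone.

Working notes on the salicylamide series. Three compounds have numbers or limits in an assay on lysate for inhibition of phosphatidylcholine:ceramide cholinephosphotransferase 2 (Homo sapiens), read by HPLC, with stated times of 30 min and 2 h; a lower number here means a stronger inhibitor, a higher number a weaker inhibitor. Compound 1, `O=C(NC1CCCNC1)c1ccccc1OCc1ccccc1Cl`, gives only a limit in this assay, > 100000 nM. Compound 2, `O=C(Nc1cccnc1)c1ccccc1OCc1ccccc1Cl`, gives 1100 nM in this assay. Compound 3, `Cc1ccccc1COc1ccccc1C(=O)Nc1cccnc1`, gives 1500 nM in this assay and so holds the highest of the two numbers, with compound 2 as its nearest neighbour; the two sit within the scatter of each other, so no order between them is claimed.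

Two steps are in hand. The first, an at least 90-fold lower number from compound 1 to compound 2 (1.95 log units; beyond the scatter), concerns the amide-side ring and is far from the benzyl ether. The second, a 1.4-fold higher number from compound 2 to compound 3 (0.13 log units; within the scatter), is a swap at the same carbon that is changed here and moved the number little.

Compound 4, `N#Cc1ccccc1COc1ccccc1C(=O)Nc1cccnc1`, differs from compound 3 by cyano in place of methyl on an aromatic carbon. The step that bears on this place is the chloro-to-methyl swap, which stayed within the scatter, so the expected step of a 1.2-fold higher number from compound 3 to compound 4 (0.08 log units; within the scatter) is likewise no change beyond the scatter, with a wide margin for the different group. Compound 4 is therefore estimated at 1800 nM in this assay, with a range from 600 nM to 6000 nM.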

Compound 4, half-maximal inhibitory concentration: 31800 nM
Compound 4: middle estimate off by 18-fold (1.25 log units), on the low side; measured number above the stated range.
By their numbers in this assay, from the lowest: compounds 2 and 3 (each within the scatter of the next); then compound 4. At a limit, above all of these: compound 1.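

The carbon ortho to a large group on the benzyl ring is not indifferent to its substituent in this assay: chloro and methyl stay within the scatter of each other, yet cyano stands well apart from both (a 21-fold higher number from compound 3 to compound 4 (1.33 log units; beyond the scatter); a 29-fold higher number from compound 2 to compound 4 (1.46 log units; beyond the scatter)). The quiet chloro-to-methyl swap therefore described that pair only and does not extend to every group at this carbon, and the series now has a single place where one small substituent change moves the number by a large step on the pyridin-3-yl amide. By count, cyano brings one more heavy atom than methyl, a triple bond and a hydrogen-bond acceptor, but no measured property of these groups bears on the step, and none of these differences can be singled out as the one that matters.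

On these data alone, whether the large step belongs to cyano alone or would also appear with a methoxy, an amine, a carboxylic acid or plain hydrogen at this carbon remains open. Also open, as far as these compounds go, is whether moving cyano to another carbon of the same ring would give a similar number.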